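Chloro on the pendant phenyl of a vanillin chalcone

The compounds below may be only part of what the source reports. "The series", "measured", "known", "first", "only" and "open" are said of these compounds alone.

Measured compounds:
Compound 1, `COc1cc(/C=C/C(=O)c2cccc(-n3cc(-c4ccccc4)[nH]c3=O)c2)ccc1O`: 1950 nM
Compound 2, `COc1cc(/C=C/C(=O)c2cccc(-n3cc(-c4ccccc4)[nH]c3=O)c2)cc(OC)c1OC`: 1400 nM

The two measured compounds were tested in a functional assay on NCI-H460 cells (Homo sapiens) for inhibition; a higher number here means a weaker inhibitor of growth, a lower number a stronger inhibitor of growth. In this assay compound 1 gives 1950 nM, and compound 2 gives 1400 nM. Among the compounds with values here, the two values lie within the usual scatter of each other, so nothing separates compound 1 from compound 2 on these numbers; compound 1 simply shares the same level with its only neighbour.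

Compound 3, `COc1cc(/C=C/C(=O)c2cccc(-n3cc(-c4ccc(Cl)cc4)[nH]c3=O)c2)ccc1O`, has not yet been measured. Relative to compound 1 the change is chloro in place of hydrogen on an aromatic carbon. Within the data shown here, no step between measured compounds is available to guide this change. A small step from compound 1 to compound 3 is expected, in either direction, not beyond the scatter, as a 1.3-fold lower number from compound 1 to compound 3 (0.11 log units; within the scatter). For compound 3 the value in this assay is expected near 1500 nM, with a range from 600 nM to 4000 nM.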

Compound 3, concentration for 50% growth inhibition: 3900 nM
The estimate for compound 3 lay 2.6-fold (0.41 log units) below the measured number; low and high end bracket the measured number.
By their numbers in this assay, from the lowest: compounds 2, 1 and 3 (each within the scatter of the next, the first and the last beyond it).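

In this assay, within the data shown here, the change from phenyl to 4-chlorophenyl gives a 2.0-fold higher number from compound 1 to compound 3 (0.30 log units; within the scatter) and is the first look at this position, which the earlier compounds left unexplored. A chloro para to a large group therefore leaves compound 3 at a level not separated from that of compound 1, although the step reaches the limit of the scatter without passing it. Nothing available here bears on what lies behind this step.

On these data alone, whether a different group at this place, such as a methoxy, an amine or a carboxylic acid, would move the number beyond the scatter remains open. Also open, as far as these compounds go, is whether chloro would give a similar step on the pendant phenyl of compound 2, whose other aromatic ring carries a different pattern of substituents.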